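The source may hold more compounds than are shown below. What is called first, only, known or untested is meant among the compounds shown, and "the series" means these compounds.

Compound 1 `COc1cc(/C=C/C(=O)OCCCCCCO[N+](=O)[O-])ccc1O`: > 50000 nM
Compound 2 `O=C(/C=C/c1ccc(OCCCCCCO[N+](=O)[O-])c(O)c1)OCCCCCCO[N+](=O)[O-]`: > 50000 nM

Both compounds were tested in a functional assay on Calu-1 cells (Homo sapiens) for cytotoxicity, read by resazurin assay, with a stated time of 72 h; on this read-out higher numbers stand for weaker inhibition and lower numbers for stronger inhibition. There, compound 2 gives > 50000 nM, which is a limit of the assay and not a number. Compound 1 gives > 50000 nM, which is also a limit. So no exact value is available for either compound, and the only evidence is the limit of > 50000 nM in this assay, at which 2 of the 2 values shown sit.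

Compound 3 `COc1cc(/C=C/C(=O)OCCCCCCO[N+](=O)[O-])ccc1OCCCCCCO[N+](=O)[O-]` differs from compound 2 at one place, methyl in place of hydrogen on an oxygen on an aromatic ring, or hydroxy to methoxy.

For the measured compounds named here, no measured step shows what this change does in this assay. Going by the values given here, with the limit of > 50000 nM in this assay, at which 2 of the 2 values shown sit, as the only guide, no change beyond the usual scatter is expected. The expected step is a number no higher from compound 2 to compound 3 (the limit leaves the size open). For compound 3, the estimated value is 50000 nM, with an expected range of 20000 nM to 100000 nM.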

Compound 3, half-maximal inhibitory concentration: 27800 nM
The estimate for compound 3 lay 1.8-fold (0.25 log units) above the measured number; the measured number falls inside the stated range.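

In this assay, compound 3 is the first of these compounds to give an exact number and not a limit, so both oxygens on the aromatic ring now carry a group and some activity can be read. Methyl in place of hydrogen on an oxygen on an aromatic ring gives an at least 1.7-fold lower number from compound 2 to compound 3 (0.25 log units; that floor lies within the scatter), and the single difference in the remaining pair gives an at least 1.7-fold lower number from compound 1 to compound 3 (0.25 log units; that floor lies within the scatter). Both steps are only floors, so neither change is shown to go beyond the scatter, and the true sizes remain unknown: the limit of > 50000 nM in this assay, at which 2 of the 3 values shown sit.

Going by these compounds, whether a larger group such as ethyl or benzyl on that oxygen would lower the number further stays open. So does the effect of an amine or a carboxylic acid at the end of the chain.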